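Chain lengthening on a macrolide amide side chain

The compounds below may be only part of what the source reports. "The series", "measured", "known", "first", "only" and "open" are said of these compounds alone.

In a physicochemical assay for lipophilicity, read by HPLC, measured as chromatographic lipophilicity, at pH 7.4 (on this read-out lower numbers stand for lower lipophilicity and higher numbers for higher lipophilicity), compound 2 `CCCCC(=O)NCCCO[C@@H]1[C@@H](C)N(C)C[C@H](C)C[C@@](C)(O)[C@H](O[C@@H]2O[C@H](C)C[C@H](N(C)C)[C@H]2O)[C@@H](C)[C@H](O[C@H]2C[C@@](C)(OC)[C@@H](O)[C@H](C)O2)[C@@H](C)C(=O)O[C@H](CC)[C@@]1(C)O` gives 3.74, the highest of the two numbers at hand. Compound 1 `CC[C@H]1OC(=O)[C@H](C)[C@@H](O[C@H]2C[C@@](C)(OC)[C@@H](OCCCNC(C)=O)[C@H](C)O2)[C@H](C)[C@@H](O[C@@H]2O[C@H](C)C[C@H](N(C)C)[C@H]2O)[C@](C)(O)C[C@@H](C)CN(C)[C@H](C)[C@@H](O)[C@]1(C)O` gives 2.06 in this assay, and the gap between the two values lies beyond the scatter. Compound 3 `CCCCCCCC(=O)NCCCO[C@@H]1[C@@H](C)N(C)C[C@H](C)C[C@@](C)(O)[C@H](O[C@@H]2O[C@H](C)C[C@H](N(C)C)[C@H]2O)[C@@H](C)[C@H](O[C@H]2C[C@@](C)(OC)[C@@H](O)[C@H](C)O2)[C@@H](C)C(=O)O[C@H](CC)[C@@]1(C)O` differs from compound 2 by propyl in place of hydrogen on a saturated chain carbon, four bonds along the chain from a carbonyl carbon. No measured step of this kind exists among these compounds, so the expected change is judged from the structural change alone: an upward step in this assay, well beyond the scatter, is expected, namely a number 1.36 log units higher from compound 2 to compound 3 (beyond the scatter). Compound 3 is therefore estimated at 5.1, with a range from 4.5 to 5.7.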

Compound 3, distribution coefficient: 5.18
Compound 3: the middle estimate sits 0.08 log units below what was measured; the measured number falls inside the stated range.
By their numbers in this assay, from the lowest: compound 1; then compound 2; then compound 3.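

Propyl in place of hydrogen on a saturated chain carbon, four bonds along the chain from a carbonyl carbon, gives the first comparison in which the compounds differ in one place: this assay reads a number 1.44 log units higher from compound 2 to compound 3 (beyond the scatter). This shows that the read-out at this position responds strongly to the added propyl. Nothing at hand accounts for the size of this step.

From the compounds shown here alone, a longer chain, or an amine at the end of this chain, remains open. Nor can this single step show whether the read-out rises evenly along the chain.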